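Shortening the Sulfanyl Chain and Cytotoxicity

The source may report more compounds than this note shows. Statements on the series, on what has been measured and on what is new or still open speak of the compounds shown alone.

For the measured compounds named here, compound 1 `CCCSc1nc(N)nc2c1ncn2/C=C1/CC1(CO)CO` is the only compound here with a number rather than a limit: in an ADME assay on CCRF-HSB-2 cells (Homo sapiens) for cytotoxicity, with a stated time of 7 days (on this read-out lower numbers stand for higher toxicity in this test and higher numbers for lower toxicity in this test), compound 1 gives 98000 nM. Compound 2 `CC(C)Nc1nc(N)nc2c1ncn2/C=C1/CC1(CO)CO` carries an isopropylamino in place of the propylsulfanyl on an aromatic carbon. In this assay compound 2 gives > 20000 nM, which is a limit of the assay and not a number. The step that the limit leaves unreadable from compound 1 to compound 2 therefore cannot be read because of the limit of > 20000 nM in this assay, at which 1 of the 2 values shown sits. Compound 3 `CSc1nc(N)nc2c1ncn2/C=C1/CC1(CO)CO` differs from compound 1 by hydrogen in place of ethyl on a saturated chain carbon bound to a sulfur. Going by the values given here, no measured step covers this change, and the one step that exists is unreadable, so the expectation rests on the structural change alone: a step beyond the scatter is not expected in either direction. Compound 3 is estimated to give 100000 nM, between 30000 nM and 300000 nM, in this assay. This estimate corresponds to an expected step of a 1.0-fold higher number from compound 1 to compound 3 (0.01 log units; within the scatter).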

Compound 3, half-maximal cytotoxic concentration: > 100000 nM
Compound 3: only a limit was reported; the forecaster's own chance of this, stated with the estimate: 30%; the middle value sits exactly at the limit.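

In this assay compound 3 gives > 100000 nM, which is a limit of the assay and not a number. Propylsulfanyl to methylsulfanyl on the shared core is the first change here that keeps the sulfur, and it gives an at least 1.0-fold higher number from compound 1 to compound 3 (0.00 log units; that floor lies within the scatter), so shortening the chain shows no step towards higher toxicity in this test, though the true size of the step stays hidden. The steps that involve compound 2 cannot be read: the limit of > 20000 nM in this assay, at which 1 of the 3 values shown sits.

From the compounds shown here alone, the real number for compound 3 remains open, and with it whether the shorter chain changes the read-out at all: the limit of > 100000 nM in this assay, at which 1 of the 3 values shown sits. It also remains open how a longer chain such as butylsulfanyl, or a plain amine in the same place, would read in this assay.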